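Hexyloxyphenyl triazoles: swapping the aryl for benzyl

The source may hold more compounds than are shown below. What is called first, only, known or untested is meant among the compounds shown, and "the series" means these compounds.

Among the measured compounds shown here, compound 2 `CCCCCCOc1ccc(-n2cnnc2-c2ccc(F)cc2)cc1` gives 22 mg/kg in a functional assay on the whole organism (strain C57B/6) with Mus musculus as the target, in the maximal electroshock model; a higher number here means that more compound is needed for the effect, a lower number that less compound is needed; it stands lowest of the two numbers so far, with compound 1 `CCCCCCOc1ccc(-n2cnnc2C)cc1` nearest at 22.8 mg/kg, a gap within the scatter. The next compound, compound 3 `CCCCCCOc1ccc(-n2cnnc2Cc2ccccc2)cc1`, differs from compound 2 by benzyl in place of 4-fluorophenyl on an aromatic carbon. For the measured compounds named here, the only step that bears on this position, a 1.0-fold lower number from compound 1 to compound 2 (0.02 log units; within the scatter), moved the number not at all. No directional effect is therefore expected in this assay from the step to compound 3. The estimated value for compound 3 is 22 mg/kg, within 10 mg/kg to 50 mg/kg, which is expected to mean no change at the digits printed from compound 2 to compound 3 (within the scatter).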

Compound 3, dose for half-maximal effect: 19 mg/kg
Beside the measured number, compound 3's estimate is 1.2-fold (0.06 log units) above it; the measured number falls inside the stated range.
By their numbers in this assay, from the lowest: compounds 3, 2 and 1 (each within the scatter of the next).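

With benzyl in place of 4-fluorophenyl, the result in this assay is a 1.2-fold lower number from compound 2 to compound 3 (0.06 log units; within the scatter), so a phenyl ring held on a saturated chain carbon and one bound directly to the aromatic carbon give numbers inside the scatter of each other. Phenyl in place of hydrogen on that chain carbon gives a 1.2-fold lower number from compound 1 to compound 3 (0.08 log units; within the scatter) and adds a whole ring without moving the number beyond the scatter. Nothing available explains why this position is so flat. From the compounds shown here alone, whether it stays flat with an amine, a carboxylic acid or a phenethyl group remains open.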